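From Compound 2 to Compound 4: a Substituent Swap

The source may report more compounds than this note shows. Statements on the series, on what has been measured and on what is new or still open speak of the compounds shown alone.

Of the compounds shown here, three have so far been tested in a functional assay on QGY7701 cells (Homo sapiens) for cytotoxicity, read by MTT assay, with a stated time of 48 h; a lower number here means a stronger inhibitor, a higher number a weaker inhibitor. Compound 1 `O=c1ccoc2cc(OCc3cn(Cc4ccc(Cl)cc4Cl)nn3)ccc12` gives 13300 nM, and compound 3 `C#CCOc1ccc2c(=O)ccoc2c1`, which carries a much shorter side chain on the shared core, gives 58500 nM. Compound 2 `O=c1ccoc2cc(OCc3cn(Cc4cccc(F)c4)nn3)ccc12` reaches only the limit of the assay, > 100000 nM, so it has no number of its own and stands as the weakest-looking member of the set on the evidence available. Among the compounds with values here, the step of an at least 7.5-fold higher number from compound 1 to compound 2 (0.87 log units; beyond the scatter) shows that changing the aromatic ring on the saturated chain carbon bound to an aromatic nitrogen can weaken inhibition considerably; it is the only measured step that touches this position, and because it ends at the limit of > 100000 nM in this assay, at which 1 of the 3 values shown sits, its true size is not known.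

Compound 4 `COc1ccc(Cn2cc(COc3ccc4c(=O)ccoc4c3)nn2)cc1` differs from compound 2 by 4-methoxyphenyl in place of 3-fluorophenyl on a saturated chain carbon bound to an aromatic nitrogen. Within the data shown here, no measured pair covers this exact exchange, so the direction of the step cannot be read from the data; the one related step warns that this position matters, but it does not say whether a methoxy-bearing ring helps or hurts. Compound 4 is therefore expected to remain weak, with an estimate of 70000 nM and a range from 20000 nM to 150000 nM. This expected change amounts to an at least 1.4-fold lower number from compound 2 to compound 4 (0.15 log units; that floor lies within the scatter).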

Compound 4, half-maximal inhibitory concentration: 56600 nM
Estimate against measurement, compound 4: 1.2-fold (0.09 log units) above; low and high end bracket the measured number.
By their numbers in this assay, from the lowest: compound 1; then compounds 4 and 3 (each within the scatter of the next). At a limit, above all of these: compound 2.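

With compound 4, this position in this assay has a second ring that gives a real number, so the 2,4-dichlorophenyl group of compound 1 can now be compared with a partner that does not end at a limit: the exchange for 4-methoxyphenyl gives a 4.3-fold higher number from compound 1 to compound 4 (0.63 log units; beyond the scatter). Among the three rings tested on this saturated chain carbon bound to an aromatic nitrogen, 2,4-dichlorophenyl therefore gives the lowest number, with both of its steps beyond the scatter, although that step is only modest. The change from 3-fluorophenyl to 4-methoxyphenyl gives an at least 1.7-fold lower number from compound 2 to compound 4 (0.24 log units; that floor lies within the scatter), and it cannot be called a clear gain because compound 2 has a limit rather than a number, which leaves the true size of the step unknown: the limit of > 100000 nM in this assay, at which 1 of the 4 values shown sits.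

The three rings differ in more than one feature, so the compounds shown cannot say which part of each ring sets the number. As far as these compounds go, it also remains open how a plain phenyl ring, or a ring carrying an amine or a carboxylic acid, would behave on this carbon.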